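Methyl on the pyrazole of an ATM series, carried to a second core

The compounds below may be only part of what the source reports. "The series", "measured", "known", "first", "only" and "open" are said of these compounds alone.

Compound 1 `COCc1ccc(-c2ccc3nnc(C(N)=O)c(N[C@@H](C)c4ccn(C)n4)c3c2)cn1`: 260 nM
Compound 2 `COCc1ccc(-c2ccc3nnc(C(N)=O)c(N[C@@H](C)c4nn(C)cc4C)c3c2)cn1`: 44 nM
Compound 3 `C[C@H](Nc1c(C(N)=O)nnc2ccc(-c3ccc(OCCCN4CCCC4)nc3)cc12)c1ccn(C)n1`: 1.1 nM

In an assay on HT-29 cells for inhibition of Serine-protein kinase ATM (Homo sapiens), read by fluorescence, with a stated time of 1 h (a higher number here means a weaker inhibitor, a lower number a stronger inhibitor), compound 1 gives 260 nM, compound 2 gives 44 nM and compound 3 gives 1.1 nM. The change methyl in place of hydrogen on an aromatic carbon gives a 5.9-fold lower number from compound 1 to compound 2 (0.77 log units; beyond the scatter). Compound 4 `Cc1cn(C)nc1[C@H](C)Nc1c(C(N)=O)nnc2ccc(-c3ccc(OCCCN4CCCC4)nc3)cc12` carries the same change, (methyl in place of hydrogen on an aromatic carbon), on the core of compound 3; the two cores differ by 3-(pyrrolidin-1-yl)propoxy in place of methoxymethyl on an aromatic carbon, a change that gives a 240-fold lower number from compound 1 to compound 3 (2.37 log units; beyond the scatter). Compound 3 already shows the lowest number of the three. For compound 4 a step of a 2.8-fold lower number from compound 3 to compound 4 (0.44 log units; beyond the scatter) is expected in this assay, somewhat smaller than the earlier one because compound 3 gives 1.1 nM and so leaves less room before the lower end of the measurable range. Compound 4 is thus estimated at 0.4 nM, between 0.15 nM and 1.2 nM.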

Compound 4, half-maximal inhibitory concentration: 0.5 nM
The estimate for compound 4 lay 1.3-fold (0.10 log units) below the measured number; the range from low to high includes it.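

On the core of compound 3 the methyl again lowers the number, with a 2.2-fold lower number from compound 3 to compound 4 (0.34 log units; beyond the scatter), so the direction holds on both cores shown, though two cores set no rule for any other core. The size of the step does not carry over, and it is smaller on the core of compound 3: the same change on two cores in this assay, a 5.9-fold lower number (0.77 log units; beyond the scatter) from compound 1 to compound 2 and a 2.2-fold lower number (0.34 log units; beyond the scatter) from compound 3 to compound 4, 2.7-fold (0.43 log units) apart, beyond the scatter of two such steps
Read the other way, with an 88-fold lower number from compound 2 to compound 4 (1.94 log units; beyond the scatter), the 3-(pyrrolidin-1-yl)propoxy change remains large but is smaller with the methyl present: the same change on two cores in this assay, a 240-fold lower number (2.37 log units; beyond the scatter) from compound 1 to compound 3 and an 88-fold lower number (1.94 log units; beyond the scatter) from compound 2 to compound 4, 2.7-fold (0.43 log units) apart, beyond the scatter of two such steps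

Open, on these data alone, is how an ethyl or a chlorine in place of the methyl would behave on each core. Also open, as far as these compounds go, is whether a piperidine or a dimethylamino group in place of the pyrrolidine would keep these steps.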